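This account rests on a few compounds, and the source may have more. Where it says the series, first, only, none or still open, it means among the compounds named here.

In an ADME assay on C1866 cells (Homo sapiens) for cytotoxicity, read by MTT assay, with a stated time of 72 h (a lower number here means that less compound is needed, a higher number that more compound is needed for the effect), three compounds built on a shared core have been measured. Compound 1 `CC(C)c1c(CC2CCCCC2)nc(SCC(=O)c2ccccc2O)[nH]c1=O` gives 1.95 nM, compound 2 `CC(C)c1c(CC2CCCCC2)nc(SCC(=O)c2ccccc2)[nH]c1=O` gives 0.025 nM, and compound 3 `CC(C)c1c(CC2CCCCC2)nc(SCc2ccccc2)[nH]c1=O` gives 0.088 nM. Among these three numbers compound 3 stands second highest: its nearest neighbour is compound 2, with a 3.5-fold higher number from compound 2 to compound 3 (0.55 log units; beyond the scatter), and its furthest is compound 1, with a 22-fold lower number from compound 1 to compound 3 (1.35 log units; beyond the scatter). The third step, a 78-fold lower number from compound 1 to compound 2 (1.89 log units; beyond the scatter), concerns the same region, the group on the saturated chain carbon bound to a sulfur.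

Compound 4 `Cc1c(CC2CCCCC2)nc(SCc2ccccc2)[nH]c1=O` differs from compound 3 at a different place: methyl in place of isopropyl on an aromatic carbon. None of the three measured steps touches this place, so they offer no direct guide to what the change does. Without a precedent at this place, the change is expected to shift the number only modestly, if at all; the step expected is a 2.3-fold higher number from compound 3 to compound 4 (0.36 log units; beyond the scatter). Compound 4 is therefore estimated to give about 0.2 nM in this assay, within a range of 0.05 nM to 1 nM.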

Compound 4, half-maximal effective concentration: 1250 nM
Beside the measured number, compound 4's estimate is 6300-fold (3.80 log units) below it; measured number outside the range, above it.
By their numbers in this assay, from the lowest: compound 2; then compound 3; then compound 1; then compound 4.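

In this assay, among the compounds shown here, the aromatic carbon ortho to a cyclohexylmethyl group proves to be the most sensitive place seen so far: a 14000-fold higher number from compound 3 to compound 4 (4.15 log units; beyond the scatter) is larger than any step among the earlier compounds, all of which concern the group on the saturated chain carbon bound to a sulfur. The change looks small on paper, since isopropyl with 3 heavy atoms gives way to methyl with 1 heavy atom, and neither group has a ring, a hydrogen-bond donor or acceptor, or a net charge. Nothing available here accounts for a step of this size.

The compounds shown leave open how the number responds to other groups at this place, such as ethyl, cyclopropyl or an amine. They also leave open whether methyl has a similar effect when a benzoyl group replaces the phenyl on the chain, as in compound 2.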